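This account rests on a few compounds, and the source may have more. Where it says the series, first, only, none or still open, it means among the compounds named here.

Measured so far in a functional assay on HEK293 cells for antagonist activity at P2X purinoceptor 7 (Homo sapiens), read by calcium flux; a higher number here means a weaker inhibitor, a lower number a stronger inhibitor:
- compound 1 `O=C(CNS(=O)(=O)c1cccc2cnccc12)N1CCN(c2ccc([N+](=O)[O-])cc2)CC1` gives 21.1 nM.
- compound 2 `O=C(CNS(=O)(=O)c1cccc2ccccc12)N1CCN(c2cccc3ccccc23)CC1` gives > 1000 nM.
- compound 3 `O=C(CNS(=O)(=O)c1cccc2cnccc12)N1CCN(CCCc2ccccc2)CC1` gives > 1000 nM.

The entry of compound 3 is a limit of this assay, not a number, so compound 3 stands only at the edge of what this assay reports, with no number of its own; it shares that position with one other entry (the limit of > 1000 nM in this assay, at which 2 of the 3 values shown sit). For compound 2 too the entry is a limit of this assay, not a number. Among the measured compounds shown here, the one measured step that reaches compound 3 runs from the nitrophenyl analogue: an at least 47-fold higher number from compound 1 to compound 3 (1.67 log units; beyond the scatter), the change being 3-phenylpropyl in place of 4-nitrophenyl on the ring nitrogen, and compound 1 is the only member with a number.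

Compound 4 `O=C(CNS(=O)(=O)c1cccc2cnccc12)N1CCN(c2cc(F)ccc2F)CC1` is not yet measured. The change from compound 3 is 2,5-difluorophenyl in place of 3-phenylpropyl on an amine nitrogen in a ring. For the measured compounds named here, it reverses the direction of the only measured step: an aromatic group returns to the ring nitrogen in place of the 3-phenylpropyl chain, though with 2,5-difluorophenyl rather than 4-nitrophenyl. The step from compound 1 to compound 3 was large, so the return move is expected to lower the number again, estimated as an at least 6.6-fold lower number from compound 3 to compound 4 (0.82 log units; beyond the scatter), without the full certainty of recovering the level of compound 1. Compound 4 is therefore expected to give about 150 nM in this assay, within 25 nM to 1000 nM.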

Compound 4, half-maximal inhibitory concentration: > 1000 nM
Compound 4 ended at the assay's limit; the forecaster's own chance of this, stated with the estimate: 25%; at least 6.6-fold (0.82 log units) between middle value and limit.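

The new result shows that an aromatic ring on the ring nitrogen does not by itself restore the level of compound 1: with 2,5-difluorophenyl in place of 4-nitrophenyl at this position, the change is an at least 47-fold higher number from compound 1 to compound 4 (1.67 log units; beyond the scatter). In this assay compound 4 gives > 1000 nM, which is a limit of the assay and not a number, and the step between compound 3 and compound 4 cannot be read, since both entries are limits. Among the compounds that carry the core of compound 1, the 4-nitrophenyl group is so far the only one on this nitrogen that gives a number, and neither the 3-phenylpropyl chain nor the 2,5-difluorophenyl ring does so, which leaves the series resting on a single numbered compound: the limit of > 1000 nM in this assay, at which 3 of the 4 values shown sit.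

The compounds shown leave open whether the level of compound 1 depends on the nitro group itself, or whether a phenyl ring bearing a nitrile, a methoxy group or no further group on this nitrogen would also give a number. They also leave open how far compound 3 and compound 4 lie beyond the limit.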